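This account rests on a few compounds, and the source may have more. Where it says the series, first, only, none or still open, it means among the compounds named here.

Measured in a functional assay on the whole organism with Rattus norvegicus as the target; a lower number here means that less compound is needed, a higher number that more compound is needed for the effect:
- compound 1 `COC(=O)CC/C=C\CC[C@H]1C(=O)C[C@@H](O)[C@@H]1/C=C/CC(C)(O)CCC1CCC1`: 0.316 mg/kg
- compound 2 `COC(=O)CC/C=C\CC[C@H]1C(=O)C[C@@H](O)[C@@H]1/C=C/C[C@@](C)(O)/C=C/C1CCCC1`: 1.95 mg/kg
- compound 3 `COC(=O)CC/C=C\CC[C@H]1C(=O)C[C@@H](O)[C@@H]1/C=C/C[C@@](C)(O)/C=C/C1=CCCCC1`: > 3.16 mg/kg (a limit, not a number)

For compound 3 there is no exact value, only a limit: the limit of > 3.16 mg/kg in this assay, at which 1 of the 3 values shown sits.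

The next structure is compound 4 `COC(=O)CC/C=C\CC[C@H]1C(=O)C[C@@H](O)[C@@H]1/C=C/C[C@@](C)(O)/C=C/C1(C)CC1`, with 1-methylcyclopropyl in place of cyclohex-1-en-1-yl on a double-bonded chain carbon bound to a double-bonded chain carbon.

Among the compounds with values here, two measured steps bear on this change. The closer one is an at least 1.6-fold higher number from compound 2 to compound 3 (0.20 log units; that floor lies within the scatter). It concerns the same place, but its floor lies within the scatter, so it gives little guidance. The other is a 6.2-fold higher number from compound 1 to compound 2 (0.79 log units; beyond the scatter), which is beyond the scatter, although the ring and the chain changed together in that step.

Compound 1 carries a cyclobutyl ring and gives 0.316 mg/kg, while compound 2 carries a cyclopentyl ring and gives 1.95 mg/kg. Compound 4 also has a small ring, but it keeps the chain double bond of compound 2, so it should not be expected to match compound 1 fully.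

The expected change is an at least 3.5-fold lower number from compound 3 to compound 4 (0.54 log units; beyond the scatter), towards less compound needed, though its size is loosely fixed. Compound 4 is estimated at 0.9 mg/kg, with an expected range of 0.25 mg/kg to 3.2 mg/kg.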

Compound 4, dose for half-maximal effect: 1.34 mg/kg
Compound 4: middle estimate off by 1.5-fold (0.17 log units), on the low side; measured number inside the range.
By their numbers in this assay, from the lowest: compound 1; then compounds 4 and 2 (each within the scatter of the next). At a limit, above all of these: compound 3.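

Compound 3 carries only a limit, not an exact number, in this assay: the limit of > 3.16 mg/kg in this assay, at which 1 of the 4 values shown sits. Even so, the change to 1-methylcyclopropyl gives an at least 2.3-fold lower number from compound 3 to compound 4 (0.37 log units; beyond the scatter), which shows that the group at this place can shift the result, something the earlier step at the same place, an at least 1.6-fold higher number from compound 2 to compound 3 (0.20 log units; that floor lies within the scatter), could not show; the replacement of cyclopentyl by the same group, however, gives a 1.5-fold lower number from compound 2 to compound 4 (0.16 log units; within the scatter), so these two groups cannot be told apart here. Compound 1 still stands apart, with a 4.2-fold higher number from compound 1 to compound 4 (0.63 log units; beyond the scatter), but the ring and the chain double bond differ together in that step, so it cannot say which of them accounts for the gap.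

Still open, from the compounds shown here alone, is how 1-methylcyclopropyl would behave on the saturated chain of compound 1, and how the cyclobutyl ring would behave on the chain double bond of compound 4. The compounds shown also leave open how an open-chain group such as tert-butyl, or a phenyl ring, would fare on this double-bonded chain carbon.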